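Swapping 4-methylphenyl for 2,4-difluorophenyl at the assay limit

This account rests on a few compounds, and the source may have more. Where it says the series, first, only, none or still open, it means among the compounds named here.

Compound 1 `COc1ccc(CNC(=O)/C=C/c2coc3cc(O)ccc3c2=O)cc1` and compound 2 `Cc1ccc(CNC(=O)/C=C/c2coc3cc(O)ccc3c2=O)cc1` share one core and differ in a single group. In a functional assay on HeLa cells (Homo sapiens) for inhibition, read by MTT assay, with a stated time of 48 h (a lower number here means a stronger inhibitor, a higher number a weaker inhibitor), compound 1 gives > 100000 nM as its result, which is a limit and not a number. In this assay compound 2 gives > 100000 nM as its result, which is likewise a limit, so compound 2 has no measured potency to start from. Among the measured compounds shown here, the series so far amounts to the limit of > 100000 nM in this assay, at which 2 of the 2 values shown sit, and nothing more. For the measured compounds named here, the only measured change is a step that the two limits leave unreadable from compound 1 to compound 2 and it offers no size to carry forward, so no step beyond the scatter is expected in this assay in either direction.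

Compound 3 `O=C(/C=C/c1coc2cc(O)ccc2c1=O)NCc1ccc(F)cc1F`, not yet measured, keeps the shared core and carries 2,4-difluorophenyl in place of 4-methylphenyl on a saturated chain carbon bound to an amide-type nitrogen, and 2,4-difluorophenyl in place of 4-methylphenyl on a saturated chain carbon bound to an amide-type nitrogen sets out what that change counts up to. The estimated move is a number no higher from compound 2 to compound 3 (the limit leaves the size open) and it is expected to stay small. For compound 3 the estimate is 100000 nM with an expected range from 30000 nM to 200000 nM and a good chance that the assay again reports only a limit.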

Compound 3, half-maximal inhibitory concentration: > 100000 nM
Compound 3 ended at the assay's limit; the forecaster's own chance of this, stated with the estimate: 70%; the middle value lies on the limit itself.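

No step can be read among compound 1, compound 2 and compound 3, because all three stop at the same limit and give no number to compare: the limit of > 100000 nM in this assay, at which 3 of the 3 values shown sit.

The compounds shown leave open how strongly each one acts on these cells, and whether any group at this place on the shared core would give a measurable value in this assay.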